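The source may hold more compounds than are shown below. What is called first, only, known or untested is meant among the compounds shown, and "the series" means these compounds.

Values in a functional assay on A2780 cells (Homo sapiens) for inhibition, read by sulforhodamine B assay, with a stated time of 72 h; a higher number here means a weaker inhibitor, a lower number a stronger inhibitor:
Compound 1 `O=C(NCc1ccc(S(=O)(=O)c2ccccc2)cc1)c1cc2ccncc2s1`: 14 nM
Compound 2 `O=C(NCc1ccc(S(=O)(=O)c2ccccc2)cc1)c1nc2ccncc2s1`: > 10000 nM
Compound 3 `O=C(NCc1ccc(S(=O)(=O)c2ccccc2)cc1)c1cn2ccnc2cn1`: > 10000 nM

Compound 3 reads > 10000 nM, which is a limit and not a number. Compound 2 also sits at a limit, and the series shows (the limit of > 10000 nM in this assay, at which 2 of the 3 values shown sit). Only compound 1 has a true number.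

Compound 4 `O=C(NCc1ccc(S(=O)(=O)c2ccccc2)cc1)c1c[nH]c2ccncc12` changes only the group on the carbonyl carbon of compound 3: a group of 9 heavy atoms (7 carbon, 2 nitrogen; one five-membered aromatic ring with 1 hetero atom, one six-membered aromatic ring with 1 hetero atom) in place of a group of 9 heavy atoms (6 carbon, 3 nitrogen; one five-membered aromatic ring with 2 hetero atoms, one six-membered aromatic ring with 2 hetero atoms), on a carbonyl carbon. The group that enters matches the group of compound 1 in its ring counts, one five-membered aromatic ring with 1 hetero atom and one six-membered aromatic ring with 1 hetero atom, although it carries nitrogen where compound 1 carries sulfur.

Going by the values given here, two measured steps bear on this. Both an at least 710-fold higher number from compound 1 to compound 3 (2.85 log units; beyond the scatter) and an at least 710-fold higher number from compound 1 to compound 2 (2.85 log units; beyond the scatter) were large and beyond the scatter, so small changes in this group can matter greatly. Part of the step to compound 3 is expected to be recovered, given the resemblance to compound 1 at 14 nM. The expected change is a sizeable move to a lower number, estimated as an at least 20-fold lower number from compound 3 to compound 4 (1.30 log units; beyond the scatter). The estimate for compound 4 is 500 nM, with an expected range of 30 nM to 8000 nM.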

Compound 4, half-maximal inhibitory concentration: 2100 nM
The estimate for compound 4 lay 4.2-fold (0.62 log units) below the measured number; the measured number falls inside the stated range.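

In this assay, the group that enters brings the series back to a true number, with an at least 4.7-fold lower number from compound 3 to compound 4 (0.67 log units; beyond the scatter) and an at least 4.7-fold lower number from compound 2 to compound 4 (0.67 log units; beyond the scatter). Both steps give only a minimum size, as compound 2 and compound 3 each sit at a limit and not at a number: the limit of > 10000 nM in this assay, at which 2 of the 4 values shown sit.

Matching the ring counts of compound 1 does not restore its level, as a 150-fold higher number from compound 1 to compound 4 (2.18 log units; beyond the scatter) remains large, so a group carrying nitrogen where compound 1 carries sulfur is far from equivalent on this carbonyl carbon.

The compounds shown leave open whether the gap to compound 1 follows the hydrogen-bond donor of the entering group or the arrangement of its ring atoms. As far as these compounds go, how a methyl group on the ring nitrogen of compound 4, or an oxygen in place of the sulfur of compound 1, would read also remains open.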